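Aryl swap on the sulfonyl of a sulfonyl-indazole series

The compounds below may be only part of what the source reports. "The series", "measured", "known", "first", "only" and "open" are said of these compounds alone.

Measured compounds:
compound 1, `CN1CCN(c2ccc3[nH]nc(S(=O)(=O)c4ccccc4Cl)c3c2)CC1`, 101 nM
compound 2, `CC(C)Cn1nc(S(=O)(=O)c2cccc3ccccc23)c2cc(N3CCN(C)CC3)ccc21`, 1.4 nM
compound 3, `CC(C)n1nc(S(=O)(=O)c2cccc3ccccc23)c2cc(N3CCN(C)CC3)ccc21`, 1.8 nM

Of the compounds shown here, three have been tested in a functional assay on HeLa cells for antagonist activity at 5-hydroxytryptamine receptor 6 (Homo sapiens); on this read-out lower numbers stand for stronger inhibition and higher numbers for weaker inhibition. Compound 1 gives 101 nM, the highest number of the three. Compound 2, with a naphthyl group on the sulfonyl sulfur and an isobutyl group on the aromatic nitrogen, gives 1.4 nM, and compound 3 gives 1.8 nM. Going by the values given here, the only single-point step among them is a 1.3-fold higher number from compound 2 to compound 3 (0.11 log units; within the scatter), so changing the alkyl group on the aromatic nitrogen is not seen to move the read-out. Among the compounds with values here, compound 1 differs from both in more than one place, so no step for it can be separated out.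

The next compound, compound 4 `COc1cccc(S(=O)(=O)c2n[nH]c3ccc(N4CCN(C)CC4)cc23)c1`, differs from compound 1 in one place: 3-methoxyphenyl in place of 2-chlorophenyl on a sulfonyl sulfur. Within the data shown here, no measured step in this assay touches the aryl group on the sulfonyl sulfur, and the one measured step concerns a different part of the molecule, so there is no direct guide. Without such a guide the expectation for compound 4 is a step of a 1.0-fold lower number from compound 1 to compound 4 (0.00 log units; within the scatter), that is, no change beyond the scatter. Compound 4 is therefore estimated at 100 nM, with a range from 30 nM to 330 nM.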

Compound 4, half-maximal inhibitory concentration: 57 nM
For compound 4 the middle estimate is 1.8-fold (0.24 log units) above the measured one, and the stated range covers the measured number.
By their numbers in this assay, from the lowest: compounds 2 and 3 (each within the scatter of the next); then compounds 4 and 1 (each within the scatter of the next).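

The aryl group on the sulfonyl sulfur now has its first single-point step in this assay: 3-methoxyphenyl in place of 2-chlorophenyl gives a 1.8-fold lower number from compound 1 to compound 4 (0.25 log units; within the scatter). On the core shared by compound 1 and compound 4, which has no alkyl group on the aromatic nitrogen, this position therefore takes a swap of a chlorine-bearing ring for a larger methoxy-bearing ring with one hydrogen-bond acceptor, and the read-out is not seen to move. No measured evidence is available to explain this outcome.

Compound 2 and compound 3 differ from compound 4 in more than one place, so the compounds shown leave open how much of the gap in their numbers belongs to the naphthyl group on the sulfonyl sulfur and how much to the alkyl group on the aromatic nitrogen. Also open, on these data alone, is whether the flat result holds for other groups at the sulfonyl sulfur, such as 2-methoxyphenyl, 3-chlorophenyl or a pyridine ring, or for an aryl ring bearing an amine or a carboxylic acid.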